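The compounds below may be only part of what the source reports. "The series", "measured", "known", "first", "only" and "open" are said of these compounds alone.

Compound 3 `COc1cc(F)ccc1N1C(=O)CSC1c1cccc(C(=O)NCCCCc2ccccc2)c1` carries a 4-fluoro-2-methoxyphenyl group on the amide-type nitrogen of the shared core, and in a functional assay on MG-63 cells (Homo sapiens) for inhibition, read by CCK-8 assay, with a stated time of 72 h, tested at 1 uM (on this read-out higher numbers stand for more inhibition at the one concentration tested (going by the name of the read-out) and lower numbers for less inhibition), compound 3 gives 92%. In this assay compound 2 `Cc1cccc(N2C(=O)CSC2c2cccc(C(=O)NCCCCc3ccccc3)c2)c1` gives 93% and compound 1 `COc1ccc(F)cc1N1C(=O)CSC1c1cccc(C(=O)NCCCCc2ccccc2)c1` gives 86%, so compound 3 holds the second highest of the three numbers, with both a number 1 percentage points lower from compound 2 to compound 3 (within the scatter) and a number 6 percentage points higher from compound 1 to compound 3 (within the scatter) falling within the scatter. Compound 4 `COc1c(F)cccc1N1C(=O)CSC1c1cccc(C(=O)NCCCCc2ccccc2)c1` differs from compound 3 only in that aryl group: 3-fluoro-2-methoxyphenyl in place of 4-fluoro-2-methoxyphenyl on an amide-type nitrogen in a ring. Among the measured compounds shown here, the one comparable swap of one fluoro-methoxyphenyl for another, a number 6 percentage points higher from compound 1 to compound 3 (within the scatter), stayed within the scatter, so no step beyond the scatter is expected here. The expected step is a number 2 percentage points lower from compound 3 to compound 4 (within the scatter). Compound 4 is therefore estimated at 90%, between 80% and 97%.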

Compound 4, a percentage reported as inhibition, at one concentration (the size of the read-out at that concentration, not a potency): 0%
Compound 4: the middle estimate sits 90 percentage points above what was measured, outside the stated range (below it).
By their numbers in this assay, from the lowest: compound 4; then compounds 1, 3 and 2 (each within the scatter of the next).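

Moving only the fluorine on the aryl group gives a number 92 percentage points lower from compound 3 to compound 4 (beyond the scatter) in this assay and thus shows that, at this place on the amide-type nitrogen, fluoro-methoxyphenyl isomers are not interchangeable, which the earlier compounds had not revealed. The other two steps, a number 86 percentage points lower from compound 1 to compound 4 (beyond the scatter) and a number 93 percentage points lower from compound 2 to compound 4 (beyond the scatter), set the 3-fluoro-2-methoxyphenyl group apart from all three other aryl groups. No available evidence bears on this loss.

On these data alone, whether a chlorine or an amine in place of that fluorine would give the same loss remains open. So does the behaviour of compound 4 at other concentrations.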